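Methoxy for trifluoromethyl in a sulfonamide series

The source may report more compounds than this note shows. Statements on the series, on what has been measured and on what is new or still open speak of the compounds shown alone.

Measured compounds in an assay on cells for inhibition of HSP60/HSP10 (Homo sapiens), with a stated time of 60 min; on this read-out higher numbers stand for weaker inhibition and lower numbers for stronger inhibition:
compound 1 `COc1ccc(S(=O)(=O)Nc2ccc3oc(-c4ccccc4)nc3c2)cc1`: > 100000 nM (a limit of the assay, not a number)
compound 2 `O=S(=O)(Nc1ccc2oc(-c3ccccc3)nc2c1)c1ccc(C(F)(F)F)cc1`: > 100000 nM (a limit of the assay, not a number)
compound 3 `O=S(=O)(Nc1ccc(-c2nc3ccccc3o2)cc1)c1ccc(C(F)(F)F)cc1`: 50000 nM

Among the measured compounds shown here, compound 3 is the only compound with a number in this assay; the other two values sit at the limit of > 100000 nM in this assay, at which 2 of the 3 values shown sit. The step that the two limits leave unreadable from compound 2 to compound 1 is therefore unreadable, since both ends are limits. The change methoxy in place of trifluoromethyl on an aromatic carbon is the same change as methoxy in place of trifluoromethyl on an aromatic carbon, the two place lines agreeing word for word. How the core of compound 3 differs from that of compound 2 is not broken down here.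

Compound 4 `COc1ccc(S(=O)(=O)Nc2ccc(-c3nc4ccccc4o3)cc2)cc1` is not yet measured. Because the same change is unreadable in a step that the two limits leave unreadable from compound 2 to compound 1, no size can be taken from it; the expectation for compound 4 rests on compound 3 at 50000 nM and on the compounds at the limit of > 100000 nM in this assay, at which 2 of the 3 values shown sit, so the step of a 1.2-fold higher number from compound 3 to compound 4 (0.08 log units; within the scatter) is expected to be small. Compound 4 is estimated at 60000 nM, between 15000 nM and 200000 nM, with a real chance of a limit only.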

Compound 4, half-maximal inhibitory concentration: > 100000 nM
Compound 4: no number, only a limit; the forecaster's own chance of this, stated with the estimate: 45%; at least 1.6-fold (0.22 log units) between middle value and limit.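

In this assay, methoxy in place of trifluoromethyl on the core of compound 3 gives an at least 2.0-fold higher number from compound 3 to compound 4 (0.30 log units; that floor lies within the scatter). This step ends on a limit for compound 4, so it gives only a floor, and that floor does not establish a change beyond the scatter. The same change on the core of compound 2 cannot be read, so the two cores cannot be compared and carry-over of the change is neither shown nor ruled out, because the read-out is capped for nearly the whole set: the limit of > 100000 nM in this assay, at which 3 of the 4 values shown sit.

From the compounds shown here alone, whether an amine or a carboxylic acid on that aromatic carbon would give a number on either core remains open. Also open, going by these compounds, is how far compound 4 actually lies from compound 3.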